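A few compounds are considered here, and "the series" means these few. Any claim that something is new, unique, unknown or untested is made for them only; others in the source may bear on it.

Compound 1 `COc1ccc(Cn2c(-c3ccccc3)c(-c3ccccc3)c3c(=N)n([C@H]4CC[C@H](O)CC4)cnc32)cc1` carries a 4-hydroxycyclohexyl group on the shared core. In an ADME assay for permeability, using PAMPA, with a stated time of 30 min, at pH 7.4 (a higher number here means that the compound crosses the layer faster, a lower number that the compound crosses the layer more slowly), compound 1 gives > 1000 10^-6 cm/s, which is a limit of the assay rather than a number. Compound 2 `N=c1c2c(-c3ccccc3)cn(Cc3ccccc3)c2ncn1CCO` belongs to the same set, and in this assay compound 2 gives 1270 10^-6 cm/s. On the numbers shown, compound 1 therefore stands at the upper edge of what the assay reports, (the limit of > 1000 10^-6 cm/s in this assay, at which 1 of the 2 values shown sits). Compound 3 `COc1ccc(Cn2c(-c3ccccc3)c(-c3ccccc3)c3c(=N)n(CC4CCCO4)cnc32)cc1` has not yet been measured. It differs from compound 1 in one place: (oxolan-2-yl)methyl in place of 4-hydroxycyclohexyl on an aromatic nitrogen. For the measured compounds named here, no measured pair covers a change of this kind, so the expectation rests on compound 1 alone. Compound 3 is expected to stay within the scatter of compound 1, the step that the limit leaves unreadable from compound 1 to compound 3 meaning no change beyond the scatter. The estimate for compound 3 in this assay is 1300 10^-6 cm/s, between 700 10^-6 cm/s and 2500 10^-6 cm/s, and it may well come back as a limit once more.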

Compound 3, apparent permeability: > 1000 10^-6 cm/s
Compound 3 was reported as a limit; the forecaster's own chance of this, stated with the estimate: 70%; the middle value is on the limit's open side.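

In this assay, for the compounds shown here, compound 3 gives > 1000 10^-6 cm/s, a limit of the assay and not a number, as is the result for compound 1, so no step from compound 1 to compound 3 can be read: the limit of > 1000 10^-6 cm/s in this assay, at which 2 of the 3 values shown sit. The compounds shown leave open whether (oxolan-2-yl)methyl in place of 4-hydroxycyclohexyl shifts the apparent permeability at all.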